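The source may hold more compounds than are shown below. What is called first, only, known or untested is meant among the compounds shown, and "the series" means these compounds.

Of the compounds shown here, three have been measured in a functional assay on HCT-116 cells (Homo sapiens) for inhibition, read by sulforhodamine B assay, with a stated time of 72 h (a lower number here means a stronger inhibitor, a higher number a weaker inhibitor), and a fourth waits for its number. Compound 1 `COc1ccc2cc(C(C)c3nnc4n3N=C(c3ccc(Cl)cc3Cl)CS4)ccc2c1` gives 14000 nM, the highest of the three numbers. Compound 2 `CC(C)Cc1ccc(C(C)c2nnc3n2N=C(c2ccc(F)cc2)CS3)cc1` gives 12400 nM, and compounds 1 and 2 give numbers within the scatter of one another, so nothing separates them. For the measured compounds named here, compound 3 `Cc1ccc(C2=Nn3c(nnc3C(C)c3ccc(CC(C)C)cc3)SC2)cc1` gives 4000 nM, and the only single change on record, a 3.1-fold lower number from compound 2 to compound 3 (0.49 log units; beyond the scatter), shows that swapping a small group on the ring attached to the carbon with a double bond to nitrogen can shift the number modestly.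

Compound 4 `COc1ccc2cc(C(C)c3nnc4n3N=C(c3ccc(OC(F)(F)F)cc3)CS4)ccc2c1` differs from compound 1 at that same carbon: 4-(trifluoromethoxy)phenyl in place of 2,4-dichlorophenyl on a carbon with a double bond to nitrogen. Going by the values given here, no measured step covers this exact exchange, so the step from compound 2 to compound 3 is the nearest guide, and it points to a change of modest size in this assay, its direction unknown. Compound 4 is therefore expected to give about 9000 nM, somewhere between 3000 nM and 27000 nM, an estimated step of a 1.6-fold lower number from compound 1 to compound 4 (0.19 log units; within the scatter).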

Compound 4, half-maximal inhibitory concentration: 11700 nM
The estimate for compound 4 lay 1.3-fold (0.11 log units) below the measured number, and the stated range covers the measured number.
By their numbers in this assay, from the lowest: compound 3; then compounds 4, 2 and 1 (each within the scatter of the next).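

In this assay, the exchange of 2,4-dichlorophenyl for 4-(trifluoromethoxy)phenyl gives a 1.2-fold lower number from compound 1 to compound 4 (0.08 log units; within the scatter), so the two groups cannot be told apart here, although the entering group has more heavy atoms and a hydrogen-bond acceptor that the leaving group lacks. For the compounds shown here, on its own, a 3.1-fold lower number from compound 2 to compound 3 (0.49 log units; beyond the scatter) showed only that a change on this ring can move the number beyond the scatter; the new step shows that, on the core of compound 1, a change of ring substituents need not do so. No measurement available here explains this result.

From the compounds shown here alone, it remains open whether an amine or a carboxylic acid on this ring would move the number. Going by these compounds, it is also open whether the methyl of compound 3 would have a comparable effect on the core of compound 1.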